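The compounds below may be only part of what the source reports. "The series", "measured", "known", "first", "only" and "open" are said of these compounds alone.

Compound 2 `Cc1cc(NC(=O)Nc2ccc(F)cc2)c2ccccc2n1` was tested in an ADME assay on HEK293 cells (Homo sapiens) for cytotoxicity, with a stated time of 72 h; on this read-out higher numbers stand for an effect only at larger amounts of compound and lower numbers for an effect already at smaller amounts. In this assay compound 2 gives > 25000 nM, which is a limit of the assay rather than a number. Two close relatives share its core and its urea link. Compound 1 `Cc1cc(NC(=O)Nc2ccc(C(C)(C)C)cc2)c2ccccc2n1` gives in this assay > 25000 nM, also a limit. Compound 3 `Cc1cc(NC(=O)Nc2ccc(C(=O)O)cc2)c2ccccc2n1` gives in this assay > 25000 nM, again a limit. All three values therefore sit at the limit of > 25000 nM in this assay, at which 3 of the 3 values shown sit, and none of the steps among them can be read: a step that the two limits leave unreadable from compound 1 to compound 2, a step that the two limits leave unreadable from compound 1 to compound 3 and a step that the two limits leave unreadable from compound 2 to compound 3. Compound 2 thus stands at the same limit as its two neighbours, with no ordering among them.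

Compound 4 `Cc1cc(NC(=O)Nc2cccc(Cl)c2)c2ccccc2n1` has not yet been measured in this assay. It differs from compound 2 by 3-chlorophenyl in place of 4-fluorophenyl on an amide-type nitrogen. Among the measured compounds shown here, none of the measured steps gives a readable size, so no direction can be drawn from them; the only guide is that every value measured so far sits at the limit. The step is therefore expected to be small, a step that the limit leaves unreadable from compound 2 to compound 4, without a change beyond the scatter. Compound 4 is estimated at 30000 nM, between 15000 nM and 100000 nM, and is most likely to be reported again as a limit.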

Compound 4, half-maximal effective concentration: 21000 nM
Beside the measured number, compound 4's estimate is 1.4-fold (0.15 log units) above it; the measured number falls inside the stated range.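

In this assay compound 4 is the first of the compounds shown to give a number rather than a limit, 21000 nM, so this position on the urea can carry a change that brings the read-out inside the range of the assay. Even so, the change of 3-chlorophenyl in place of 4-fluorophenyl on an amide-type nitrogen gives only an at least 1.1-fold lower number from compound 2 to compound 4 (0.07 log units; that floor lies within the scatter), which shows a measurable end point for compound 4 but not a real difference from compound 2, and the true size of the step stays unknown. The number for compound 4 therefore stands alone among values that otherwise remain at the assay's limit: the limit of > 25000 nM in this assay, at which 3 of the 4 values shown sit.

The compounds shown do not tell whether the chlorine itself or the different placement of the halogen on the phenyl ring matters, since the two differ together in this single step. As far as these compounds go, it also remains open whether bromine, a methoxy group or an amine on the same phenyl ring would give a number in this assay or return to the limit.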